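The source may report more compounds than this note shows. Statements on the series, on what has been measured and on what is new or still open speak of the compounds shown alone.

Compound 2 `O=C(Nc1ccccc1I)N[C@H]1CC[C@H](Oc2ccc(F)cc2)CC1` stands at a limit in a functional assay on CRL2813 cells (Homo sapiens) for cytotoxicity, read by sulforhodamine B assay, with a stated time of 5 days; on this read-out lower numbers stand for stronger inhibition and higher numbers for weaker inhibition: compound 2 gives > 20000 nM, a limit of the assay and not a number. Compound 1 `O=C(Nc1ccccc1OC(F)(F)F)N[C@H]1CC[C@H](Oc2ccc(F)cc2)CC1` likewise reaches only a limit, since in this assay compound 1 gives > 20000 nM. Hence a step that the two limits leave unreadable from compound 1 to compound 2, with both values sitting at the limit of > 20000 nM in this assay, at which 2 of the 2 values shown sit. Compound 3 `O=C(Nc1ccccc1C(F)(F)F)N[C@H]1CC[C@H](Oc2ccc(F)cc2)CC1` is the next member and has not yet been measured. From compound 2 to compound 3 the change is trifluoromethyl in place of iodo on an aromatic carbon. Within the data shown here, the one measured step bears on this only in that neither the trifluoromethoxy nor the iodo compound returned a number, so no step of readable size is available and no direction beyond the scatter is expected in this assay. The step expected here is a step that the limit leaves unreadable from compound 2 to compound 3. For compound 3 the estimate is 25000 nM, with a range from 8000 nM to 80000 nM, most probably again a limit.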

Compound 3, half-maximal inhibitory concentration: > 20000 nM
Compound 3 ended at the assay's limit (the forecaster's own chance of this, stated with the estimate: 80%); the middle value is on the limit's open side.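

No step can be read among compound 1, compound 2 and compound 3 in this assay, since each value is a limit and not a number: the limit of > 20000 nM in this assay, at which 3 of the 3 values shown sit.

The compounds shown leave open how the trifluoromethoxy, iodo and trifluoromethyl groups rank against one another.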